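Bromo in Place of Methyl on the Sulfur-Linked Ring

The source may hold more compounds than are shown below. What is called first, only, known or untested is meant among the compounds shown, and "the series" means these compounds.

Of the compounds shown here, three sharing one core have been measured in a functional assay on A-375 cells (Homo sapiens) for inhibition, read by CCK-8 assay, with a stated time of 72 h, tested at 2 uM; on this read-out lower numbers stand for less inhibition of growth and higher numbers for more inhibition of growth at the one concentration tested. Compound 1 `COc1ccc(SCc2ccc(C(=O)Nc3ccccc3N)cc2)cc1` gives 10.2%. Compound 2 `Nc1ccccc1NC(=O)c1ccc(CSc2cccc(F)c2)cc1` gives 37.7%, and compound 3 `Cc1ccc(SCc2ccc(C(=O)Nc3ccccc3N)cc2)cc1` gives 17.5%. Compound 3 thus holds the second highest of the three numbers: its gap to compound 1 lies within the scatter (a number 7.3 percentage points higher from compound 1 to compound 3 (within the scatter)), while its gap to compound 2 lies beyond it (a number 20.2 percentage points lower from compound 2 to compound 3 (beyond the scatter)).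

Compound 4 `Nc1ccccc1NC(=O)c1ccc(CSc2ccc(Br)cc2)cc1` differs from compound 3 in one place: bromo in place of methyl on an aromatic carbon. The change sits on the ring carried by the sulfur, the same ring altered in the measured steps. There, a number 27.5 percentage points higher from compound 1 to compound 2 (beyond the scatter) and a number 20.2 percentage points lower from compound 2 to compound 3 (beyond the scatter) show that the group on this ring shifts the read-out by modest amounts, whereas a number 7.3 percentage points higher from compound 1 to compound 3 (within the scatter) shows a difference within the scatter. None of these steps involves bromo, and none puts fluoro at the place now changed, so the direction for compound 4 remains uncertain. Because a number 20.2 percentage points lower from compound 2 to compound 3 (beyond the scatter) links the fluoro-bearing compound 2 to the higher number, a modest rise for compound 4 is expected, namely a number 7.5 percentage points higher from compound 3 to compound 4 (within the scatter). Compound 4 is therefore estimated at 25%, within a range from 8% to 45%.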

Compound 4, percent growth inhibition at one concentration: 4.35%
For compound 4 the middle estimate is 20.7 percentage points above the measured one, and the stated range ends above it.
By their numbers in this assay, from the lowest: compounds 4, 1 and 3 (each within the scatter of the next, the first and the last beyond it); then compound 2.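

On the ring carried by the sulfur, with the group para to a large group, the earlier pair of methoxy and methyl could not be told apart, yet in this assay the change to bromo shows a number 13.2 percentage points lower from compound 3 to compound 4 (beyond the scatter) and so separates two groups at this place. Bromo and methoxy remain unresolved there, with a number 5.9 percentage points lower from compound 1 to compound 4 (within the scatter) as their difference, so compound 1 lies within the scatter of both compound 3 and compound 4, while those two lie beyond it from each other. Replacing the 3-fluorophenyl group of compound 2 with 4-bromophenyl gives a number 33.4 percentage points lower from compound 2 to compound 4 (beyond the scatter) as the largest step in the set, and compound 2 stays clearly above all three compounds that carry a group at the para place.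

The compounds shown leave open whether the higher number of compound 2 goes with fluoro itself or with where it stands on the ring, as each step to compound 2 changes both at once. They also leave open what an amine or a carboxylic acid on this ring would give. Nothing shown here explains why these groups differ.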